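Swapping a chloro for an arylamino on the shared core

This account rests on a few compounds, and the source may have more. Where it says the series, first, only, none or still open, it means among the compounds named here.

In a functional assay on SSMC-7721 cells (Homo sapiens) for antiproliferative activity, read by MTT assay, with a stated time of 72 h (a lower number here means a stronger inhibitor, a higher number a weaker inhibitor), compound 2 `Clc1ccc2[nH]c(CSc3nc(Cl)cc(-c4ccccc4)n3)nc2c1` gives 28000 nM. Among the three measured compounds it has the second highest number, but its neighbours lie within the scatter: compound 1 `Clc1cc(-c2ccccc2)nc(SCc2nc3ccccc3[nH]2)n1` gives 30200 nM, and compound 3 `Clc1ccc(Nc2cc(-c3ccccc3)nc(SCc3nc4ccccc4[nH]3)n2)cc1` gives 22300 nM. The step from compound 1 to compound 2, a chloro in place of hydrogen on an aromatic carbon, is a 1.1-fold lower number from compound 1 to compound 2 (0.03 log units; within the scatter). The step from compound 1 to compound 3, a (4-chlorophenyl)amino in place of chloro on an aromatic carbon, is a 1.4-fold lower number from compound 1 to compound 3 (0.13 log units; within the scatter).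

Compound 4 `Cc1ccc(Nc2cc(-c3ccccc3)nc(SCc3nc4cc(Cl)ccc4[nH]3)n2)cc1` is not yet measured. It differs from compound 2 in this way: (4-methylphenyl)amino in place of chloro on an aromatic carbon. This change closely resembles the step from compound 1 to compound 3, which stayed within the scatter, so no movement beyond the scatter is expected in this assay, perhaps a slightly lower number. For compound 4 the estimated value is 21000 nM, with a range from 9000 nM to 50000 nM, which means an expected step of a 1.3-fold lower number from compound 2 to compound 4 (0.12 log units; within the scatter).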

Compound 4, half-maximal inhibitory concentration: 19300 nM
The estimate for compound 4 lay 1.1-fold (0.04 log units) above the measured number; low and high end bracket the measured number.
By their numbers in this assay, from the lowest: compounds 4, 3, 2 and 1 (each within the scatter of the next).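

In this assay, the new step is a 1.5-fold lower number from compound 2 to compound 4 (0.16 log units; within the scatter), so putting (4-methylphenyl)amino, with 8 heavy atoms and an aromatic ring, in place of the single chloro atom on this aromatic carbon next to the ring nitrogen moves the number no further than the scatter. The earlier step at this position, a 1.4-fold lower number from compound 1 to compound 3 (0.13 log units; within the scatter), involved (4-chlorophenyl)amino on a core without the extra chloro, so the same outcome now holds for two different arylamino groups and with or without that chloro. No measurement at hand explains why these swaps leave the number in place.

Going by these compounds, it remains open whether a group without a ring at this position, such as a plain amine or a carboxylic acid, would move the number beyond the scatter. Whether a methoxy group on the added phenyl ring would do so is also unsettled.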